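Benzyl to 2-chlorobenzyl: what compound 3 may show

The source may hold more compounds than are shown below. What is called first, only, known or untested is meant among the compounds shown, and "the series" means these compounds.

In a functional assay on MDA-MB-231 cells (Homo sapiens) for cytotoxicity, read by MTT assay, with a stated time of 72 h (on this read-out lower numbers stand for stronger inhibition and higher numbers for weaker inhibition), compound 2 `CCN(CC)Cc1ccc2nc(NC(=O)N/N=C/c3cn(Cc4ccccc4)c4ccccc34)sc2c1` gives 1470 nM, which lies within the scatter of compound 1 `CCN(CC)Cc1ccc2nc(NC(=O)N/N=C/c3cn(Cc4ccc(C)cc4)c4ccccc34)sc2c1` at 2010 nM. Compound 3 `CCN(CC)Cc1ccc2nc(NC(=O)N/N=C/c3cn(Cc4ccccc4Cl)c4ccccc34)sc2c1` turns the benzyl of compound 2 into 2-chlorobenzyl: chloro in place of hydrogen on an aromatic carbon. Among the measured compounds shown here, the one measured step that bears on this, a 1.4-fold lower number from compound 1 to compound 2 (0.14 log units; within the scatter), is hydrogen in place of methyl on an aromatic carbon. For the measured compounds named here, with only that step as a guide, no change beyond the scatter is expected in this assay, in either direction. The expected step is a 1.1-fold lower number from compound 2 to compound 3 (0.02 log units; within the scatter). The estimate for compound 3 is 1400 nM, with an expected range of 600 nM to 3300 nM.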

Compound 3, half-maximal inhibitory concentration: 900 nM
Beside the measured number, compound 3's estimate is 1.6-fold (0.19 log units) above it; the range from low to high includes it.
By their numbers in this assay, from the lowest: compounds 3, 2 and 1 (each within the scatter of the next, the first and the last beyond it).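

In this assay, chloro in place of hydrogen on this aromatic carbon brings no clear change: a 1.6-fold lower number from compound 2 to compound 3 (0.21 log units; within the scatter). Set against the 4-methylbenzyl group, however, the 2-chlorobenzyl group gives the first gap beyond the scatter in this short series, a modest one: a 2.2-fold lower number from compound 1 to compound 3 (0.35 log units; beyond the scatter). Nothing available explains either step. As far as these compounds go, whether fluoro, methoxy or an amine in place of the chloro would move the number beyond the scatter remains open. So does whether chloro elsewhere on this six-membered ring would give a similar number.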